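Naphthyl core with fluorophenyl amide: cytotoxicity expectation

The source may hold more compounds than are shown below. What is called first, only, known or untested is meant among the compounds shown, and "the series" means these compounds.

Measured so far in an ADME assay on MT4 cells (Homo sapiens) for cytotoxicity, read by MTT assay; on this read-out higher numbers stand for lower toxicity in this test and lower numbers for higher toxicity in this test:

compound 1 `O=C(CSc1nncnc1-c1ccccc1Cl)Nc1ccccc1F`: 98000 nM
compound 2 `O=C(CSc1nncnc1-c1ccccc1Cl)Nc1cccnc1Cl`: 167000 nM
compound 3 `O=C(CSc1nncnc1-c1cccc2ccccc12)Nc1cccnc1Cl`: 44000 nM

Compound 3 has the lowest of the three numbers; its gap to compound 1 and to compound 2 is beyond the scatter. Compound 3 and compound 2 share the amide part but differ in the core; the difference between the two cores is not broken down here.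

For the measured compounds named here, the one change seen twice is 2-fluorophenyl in place of 2-chloropyridin-3-yl on an amide-type nitrogen. On the core of compound 2 it gave a 1.7-fold lower number from compound 2 to compound 1 (0.23 log units; within the scatter).

Compound 4 `O=C(CSc1nncnc1-c1cccc2ccccc12)Nc1ccccc1F` carries the same change on the core of compound 3: 2-fluorophenyl in place of 2-chloropyridin-3-yl on an amide-type nitrogen. The place is the same word for word, so this is the same change.

A step of similar size is expected, a 1.5-fold lower number from compound 3 to compound 4 (0.17 log units; within the scatter), resting on the step from compound 2 to compound 1, a 1.7-fold lower number from compound 2 to compound 1 (0.23 log units; within the scatter). Compound 4 is estimated at 30000 nM in this assay, with the range 12000 nM to 75000 nM expected to hold the measurement.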

Compound 4, half-maximal cytotoxic concentration: 65000 nM
Compound 4: middle estimate off by 2.2-fold (0.34 log units), on the low side; the range from low to high includes it.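

In this assay the step of a 1.5-fold higher number from compound 3 to compound 4 (0.17 log units; within the scatter) comes from placing 2-fluorophenyl where 2-chloropyridin-3-yl stood on an amide-type nitrogen, and it cannot be told apart from the earlier step on the other core: the same change on two cores in this assay, a 1.7-fold lower number (0.23 log units; within the scatter) from compound 2 to compound 1 and a 1.5-fold higher number (0.17 log units; within the scatter) from compound 3 to compound 4, 2.5-fold (0.40 log units) apart, within the scatter of two such steps.

On these two cores, then, the change carries over as a small step in this test. Neither step leaves the scatter, so no direction can be assigned to the change. Two cores do not make a rule for the series.

Still open, on these data alone, is whether the step stays this small with other groups on the amide nitrogen, such as a cyclohexyl ring or a longer alkyl chain. As far as these compounds go, a phenyl ring bearing a carboxylic acid is equally open.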